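From fluoro to methylsulfonyl in a cell assay

The compounds below may be only part of what the source reports. "The series", "measured", "known", "first", "only" and "open" are said of these compounds alone.

Three related compounds have numbers in a functional assay on HepG2 cells (Homo sapiens) for inhibition, read by sulforhodamine B assay, with a stated time of 72 h; a higher number here means a weaker inhibitor, a lower number a stronger inhibitor. Compound 1 `C[C@H](Nc1ncnc2[nH]cnc12)c1nn(-c2cccnc2)c2ccc(F)cc12` gives 41900 nM, compound 2 `C[C@H](Nc1ncnc2[nH]cnc12)c1nn(-c2cccc(F)c2)c2cc(F)ccc12` gives 32300 nM, and compound 3 `C[C@H](Nc1nc(N)nc(N)c1C#N)c1nn(-c2cccc(S(C)(=O)=O)c2)c2cc(Cl)ccc12` gives 1880 nM. Compound 2 therefore sits within the usual scatter of compound 1, so these two cannot be told apart, while compound 3 lies far lower, well beyond the scatter.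

Compound 4 `C[C@H](Nc1ncnc2[nH]cnc12)c1nn(-c2cccc(S(C)(=O)=O)c2)c2cc(F)ccc12` has not yet been measured. It is compound 2 with methylsulfonyl in place of fluoro on an aromatic carbon.

Within the data shown here, no measured pair in this small set isolates that swap, so its size cannot be read directly from the data. Among the measured compounds shown here, the only hint comes from compound 3, which also carries methylsulfonyl and gives 1880 nM. It differs from compound 4 in other places too, however, so only part of that much lower number can be expected to carry over. The expected step in this assay is a 2.3-fold lower number from compound 2 to compound 4 (0.36 log units; beyond the scatter), a modest move toward stronger inhibition, and a result within the scatter would be no surprise. For compound 4 the estimated value is 14000 nM, with an expected range of 4000 nM to 45000 nM.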

Compound 4, half-maximal inhibitory concentration: 14800 nM
Beside the measured number, compound 4's estimate is 1.1-fold (0.02 log units) below it; the range from low to high includes it.
By their numbers in this assay, from the lowest: compound 3; then compound 4; then compounds 2 and 1 (each within the scatter of the next).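

In this assay, among these compounds, the change from 3-fluorophenyl to 3-(methylsulfonyl)phenyl gives a 2.2-fold lower number from compound 2 to compound 4 (0.34 log units; beyond the scatter), and this is the first direct reading of the swap, with the rest of the molecule held constant. It shows that this aromatic carbon, meta to a large group, accepts a methylsulfonyl group of four heavy atoms in place of a single fluorine without any loss of inhibition; the number instead moves modestly in the stronger direction. Nothing measured here accounts for the size or direction of this step.

A single pair cannot show whether the gain comes from the whole methylsulfonyl group or only from part of it, so a sulfonamide, a methoxy group or a carboxylic acid at the same place would help separate these possibilities. Going by these compounds, it also remains open whether the same swap would give a step of similar size on a different core, since this change has so far been read only on the core shared by compound 2 and compound 4.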